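The source may hold more compounds than are shown below. What is called first, only, known or untested is meant among the compounds shown, and "the series" means these compounds.

Measured compounds:
compound 1 `O=C(NNC(=O)c1cccc([N+](=O)[O-])c1)c1ccc(-n2cccc2)cc1` — 195000 nM
compound 2 `CC(=O)N1N=C(c2ccc(-n3c(C)ccc3C)cc2)OC1c1ccccc1[N+](=O)[O-]` — 175000 nM

Both values come from an ADME assay on Vero cells (Chlorocebus sabaeus) for cytotoxicity, read by MTT assay, with a stated time of 72 h; a lower number here means a stronger inhibitor, a higher number a weaker inhibitor. Compound 2 holds the lower of the two numbers, but compound 1 sits so close that the gap lies within the scatter; no order between them can be read from these two values.

Compound 3 `CC(=O)N1N=C(c2ccc(-n3c(C)ccc3C)cc2)OC1c1ccc(O)cc1` has not been measured. Against compound 2 the change is 4-hydroxyphenyl in place of 2-nitrophenyl on a saturated ring carbon; the shared core and the acetyl group are untouched.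

For the measured compounds named here, no step between measured compounds is available, and no pair in the set shows this change, so the expected size of the step in this assay rests on the weak activity of compound 2 alone. A step of no more than the scatter, in either direction, is expected. For compound 3 the estimate in this assay is 200000 nM, with a range from 100000 nM to 400000 nM, meaning an expected step of a 1.1-fold higher number from compound 2 to compound 3 (0.06 log units; within the scatter).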

Compound 3, half-maximal inhibitory concentration: 187000 nM
The estimate for compound 3 lay 1.1-fold (0.03 log units) above the measured number, within the range that was stated.
By their numbers in this assay, from the lowest: compounds 2, 3 and 1 (each within the scatter of the next).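

In this assay, for the compounds shown here, the exchange of 2-nitrophenyl for 4-hydroxyphenyl on the saturated ring carbon gives a 1.1-fold higher number from compound 2 to compound 3 (0.03 log units; within the scatter), the first step that can be read between compounds differing in one place. This single pair shows no readable effect on the number from the exchange, although the group's atoms, its hydrogen-bond donor count and its hydrogen-bond acceptor count all differ. No measurement on hand bears on this result.

The substituent and its location on the phenyl ring change together here, so the contribution of each remains unresolved. Also open, as far as these compounds go, is whether an amine or a carboxylic acid on that phenyl ring, or a longer chain in place of the acetyl group, would move the number beyond the scatter.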